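Replacing the 4-aminophenyl group of compound 2

The source may report more compounds than this note shows. Statements on the series, on what has been measured and on what is new or still open speak of the compounds shown alone.

In a functional assay on RBL-2H3 cells (Rattus norvegicus) for inhibition, with stated times of 30 min and 1 h (on this read-out lower numbers stand for stronger inhibition and higher numbers for weaker inhibition), compound 2 `COc1ccc(CN(CCN(C)C)c2ccc(N)cc2)cc1` gives 4060 nM as the highest number of three, with compound 1 `COc1ccc(CN(CCN(C)C)c2ccccc2)cc1` at 243 nM and compound 3 `COc1ccc(CN(CCN(C)C)c2ccc(Cl)cn2)cc1` at 19.2 nM on the lower side. Compound 4 `COc1ccc(CN(CCN(C)C)c2ccc(C)cn2)cc1` is still unmeasured and carries 5-methylpyridin-2-yl in place of 4-aminophenyl on an amine nitrogen, a change counted as 5-methylpyridin-2-yl in place of 4-aminophenyl on an amine nitrogen in full. The nearest guide is a 210-fold lower number from compound 2 to compound 3 (2.33 log units; beyond the scatter) for the swap to 5-chloropyridin-2-yl. Two further large steps bear on it, a 17-fold higher number from compound 1 to compound 2 (1.22 log units; beyond the scatter) on adding the amino group and a 13-fold lower number from compound 1 to compound 3 (1.10 log units; beyond the scatter) for 5-chloropyridin-2-yl in place of phenyl. Among the measured compounds shown here, no measured compound compares methyl with chloro. A large fall in this assay is therefore expected, with a 100-fold lower number from compound 2 to compound 4 (2.01 log units; beyond the scatter) as the estimated step. Compound 4 is expected to read 40 nM with 12 nM to 150 nM as its likely range.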

Compound 4, half-maximal inhibitory concentration in the RBL-2H3 assay: 48.6 nM
Compound 4: middle estimate off by 1.2-fold (0.08 log units), on the low side; measured number inside the range.
By their numbers in the RBL-2H3 assay, from the lowest: compound 3; then compound 4; then compound 1; then compound 2.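

Compound 2 and compound 4 hold the same atoms joined differently, yet in the RBL-2H3 assay the change gives an 84-fold lower number from compound 2 to compound 4 (1.92 log units; beyond the scatter), so the atom count alone does not set the number. Methyl serves nearly as well as chloro, with a 2.5-fold higher number from compound 3 to compound 4 (0.40 log units; beyond the scatter), and 5-methylpyridin-2-yl still beats phenyl, with a 5.0-fold lower number from compound 1 to compound 4 (0.70 log units; beyond the scatter). In a physicochemical assay for lipophilicity (on this read-out higher numbers stand for higher lipophilicity and lower numbers for lower lipophilicity), compound 2 gives 3.13 and compound 4 gives 3.79, so the same change also shifts the read-out: the measured partition coefficient of compound 2, 3.13, and of compound 4, 3.79, a number 0.66 log units higher (beyond the scatter)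

From the compounds shown here alone, whether that rise in partition coefficient has any part in the fall in inhibition number stays open. So does the reading of a 5-aminopyridin-2-yl group at this place, which would carry the amino group and the ring nitrogen together.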